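The source may hold more compounds than are shown below. What is called first, only, known or untested is meant among the compounds shown, and "the series" means these compounds.

Of the compounds shown here, three sharing one core have been tested in a functional assay on CHO cells with adenosine receptor A1 (Homo sapiens) as the target, read by cAMP accumulation and immunoassay, with a stated time of 6 min, tested at 0.1 uM; a higher number here means a weaker effect of the compound at the concentration tested, a lower number a stronger effect. Compound 1 `Nc1scc(CN2CCN(c3cccc(Cl)c3Cl)CC2)c1C(=O)c1ccc(Cl)cc1` gives 3.2%. Compound 2 `Nc1scc(CN2CCN(c3cccc(C(F)(F)F)c3)CC2)c1C(=O)c1ccc(Cl)cc1` gives -30%. Compound 3 `Nc1scc(CN2CCN(c3ccc(Cl)c(C(F)(F)F)c3)CC2)c1C(=O)c1ccc(Cl)cc1` gives -12%. Within this set compound 3 stands second highest: it is separated from compound 1 by a number 15.2 percentage points lower from compound 1 to compound 3 (beyond the scatter) and from compound 2 by a number 18 percentage points higher from compound 2 to compound 3 (beyond the scatter), both beyond the scatter, so the group on the ring nitrogen plainly matters here.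

Compound 4 `Nc1scc(CN2CCN(c3c(F)cc(F)cc3F)CC2)c1C(=O)c1ccc(Cl)cc1` is the next compound. It differs from compound 3 in one place: 2,4,6-trifluorophenyl in place of 4-chloro-3-(trifluoromethyl)phenyl on an amine nitrogen in a ring. Among the compounds with values here, no measured step replaces this aryl group with a trifluorophenyl, so no step bears on the change directly. What the measured steps show is the span that such replacements cover: a number 33.2 percentage points lower from compound 1 to compound 2 (beyond the scatter) was large, and the two steps involving compound 3 were modest. A new aryl group may therefore move the read-out anywhere in that span, and the direction cannot be read from the data.

Compound 4 is accordingly expected to fall near the middle of the range seen so far, at an estimated -8%, between -35% and 15%. Against compound 3 that estimate means an expected a number 4 percentage points higher from compound 3 to compound 4 (within the scatter), which is not a confident call in either direction.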

Compound 4, a percentage reported as activity, at one concentration (the size of the read-out at that concentration, not a potency): -3.9%
The estimate for compound 4 lay 4.1 percentage points below the measured number; measured number inside the range.
By their numbers in this assay, from the lowest: compound 2; then compounds 3, 4 and 1 (each within the scatter of the next, the first and the last beyond it).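

In this assay, the 2,4,6-trifluorophenyl on the ring nitrogen carries neither a chlorine nor a trifluoromethyl group, yet compound 4 cannot be told apart from compound 3 (a number 8.1 percentage points higher from compound 3 to compound 4 (within the scatter)) or from compound 1 (a number 7.1 percentage points lower from compound 1 to compound 4 (within the scatter)). So this position accepts an aryl group without either of those substituents and the read-out stays with these two compounds, while compound 2 now stands apart from a third aryl group (a number 26.1 percentage points higher from compound 2 to compound 4 (beyond the scatter)) and keeps the lowest number of the four, a separation that the trifluoromethyl group cannot explain by its presence alone, since compound 3 carries one too. No measurement in hand gives a reason for any of these steps.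

From the compounds shown here alone, what remains open is whether the separation of compound 2 belongs to its 3-(trifluoromethyl)phenyl as a whole, which a plain phenyl, or a phenyl bearing a single methoxy or nitrile group in place of the trifluoromethyl, would help to settle. The compounds shown also leave open whether any of this carries over to a change at the 4-chlorobenzoyl part of the shared core, for example a plain benzoyl group.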